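The source may hold more compounds than are shown below. What is called first, only, known or untested is meant among the compounds shown, and "the series" means these compounds.

Measured compounds in a functional assay on CHO-K1 cells for antagonist activity at transient receptor potential cation channel subfamily V member 1 (Homo sapiens), read by FLIPR; a higher number here means a weaker inhibitor, a lower number a stronger inhibitor:
- compound 1 `Cc1ccc(Cl)cc1Nc1nc(C(F)(F)F)ccc1CNC(=O)C(C)c1ccc(NS(C)(=O)=O)c(F)c1`: 14 nM
- compound 2 `CC(C(=O)NCc1ccc(C(F)(F)F)nc1N1CCC(C(F)(F)F)CC1)c1ccc(NS(C)(=O)=O)c(F)c1`: 0.6 nM
- compound 3 `CC(C(=O)NCc1ccc(C(F)(F)F)nc1N1CCN(C)CC1)c1ccc(NS(C)(=O)=O)c(F)c1`: 146 nM

Compound 3 gives the highest number of the three in this assay; its nearest neighbour is compound 1, and compound 2 lies furthest from it. Compound 4 `CC(C(=O)NCc1ccc(C(F)(F)F)nc1N1CCN(c2ncccc2C(F)(F)F)CC1)c1ccc(NS(C)(=O)=O)c(F)c1` differs from compound 3 in one place: 3-(trifluoromethyl)pyridin-2-yl in place of methyl on an amine nitrogen in a ring. For the measured compounds named here, two measured steps bear on this change. The step of a 240-fold higher number from compound 2 to compound 3 (2.39 log units; beyond the scatter) was large, and the step of a 10-fold higher number from compound 1 to compound 3 (1.02 log units; beyond the scatter) was also large, both in the direction of weaker inhibition when the group on the shared core lost its trifluoromethyl or aryl character in favour of the small methylpiperazine. Since compound 4 restores an aryl group carrying a trifluoromethyl at that position, a large step back toward stronger inhibition is expected, estimated as an 18-fold lower number from compound 3 to compound 4 (1.26 log units; beyond the scatter). For compound 4 the expected value in this assay is 8 nM, with a range from 1.5 nM to 40 nM.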

Compound 4, inhibition constant: 2.8 nM
The estimate for compound 4 lay 2.9-fold (0.46 log units) above the measured number; the range from low to high includes it.
By their numbers in this assay, from the lowest: compound 2; then compound 4; then compound 1; then compound 3.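

In this assay, 3-(trifluoromethyl)pyridin-2-yl in place of methyl gives a 52-fold lower number from compound 3 to compound 4 (1.72 log units; beyond the scatter), showing that the amine nitrogen in the ring accepts a far larger aromatic group and that inhibition strengthens with it. The earlier steps shown here exchanged the whole group on the shared core, whereas this one keeps the ring with its two nitrogens and changes only the group on that nitrogen. Nothing measured here accounts for the gain. The compounds shown leave open whether it depends on the trifluoromethyl, the ring nitrogen of the pyridine, or the aromatic ring alone. A plain phenyl or an unsubstituted pyridin-2-yl at this nitrogen would separate these possibilities.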